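Swapping a para chloro for methoxy on a growth inhibitor

The compounds below may be only part of what the source reports. "The series", "measured", "known", "first", "only" and "open" are said of these compounds alone.

Of the compounds shown here, three sharing one core have been tested in a functional assay on SW-620 cells (Homo sapiens) for inhibition, read by sulforhodamine B assay, with a stated time of 48 h; on this read-out lower numbers stand for stronger inhibition of growth and higher numbers for weaker inhibition of growth. Compound 1 `N=C(N)c1ccc(-c2ccc(-c3cc(Cl)cc(Cl)c3)s2)cc1` gives 318 nM, and compound 2 `N=C(N)c1ccc(-c2ccc(-c3ccc(F)cc3)s2)cc1` gives 386 nM. Compound 3 `N=C(N)c1ccc(-c2ccc(-c3ccc(Cl)cc3)s2)cc1F` gives 186 nM, the lowest of the three numbers; compound 1 sits within the usual scatter of it, while compound 2 lies beyond that scatter. Compound 4 `COc1ccc(-c2ccc(-c3ccc(C(=N)N)c(F)c3)s2)cc1` has not yet been measured in this assay. It differs from compound 3 in one place (methoxy in place of chloro on an aromatic carbon). Within the data shown here, no measured pair shows what this exchange does here, so the expected step of a 1.6-fold higher number from compound 3 to compound 4 (0.21 log units; within the scatter) is small, with no clear direction beyond the scatter. On that basis compound 4 is estimated at 300 nM, with a likely range from 120 nM to 750 nM.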

Compound 4, concentration for 50% growth inhibition: 1920 nM
Estimate against measurement, compound 4: 6.4-fold (0.81 log units) below; measured number outside the range, above it.
By their numbers in this assay, from the lowest: compounds 3, 1 and 2 (each within the scatter of the next, the first and the last beyond it); then compound 4.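

In this assay, methoxy in place of chloro on this aromatic carbon, para to a large group, gives a 10-fold higher number from compound 3 to compound 4 (1.01 log units; beyond the scatter), and the step is large. Among these compounds, the earlier compounds offered no comparison differing in one place, so this is the first sign that the group at this position strongly affects the read-out, though it rests on a single pair. As far as these compounds go, whether an amine or a methyl group here would stay close to compound 3 or fall nearer to compound 4 remains open. Nothing shown explains the size of this step.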